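This account rests on a few compounds, and the source may have more. Where it says the series, first, only, none or still open, it means among the compounds named here.

Measured in a functional assay on NCI-H460 cells (Homo sapiens) for inhibition, with a stated time of 72 h; on this read-out lower numbers stand for stronger inhibition and higher numbers for weaker inhibition:
- Compound 1 `COc1cc(C(=O)c2ccc3[nH]ccc3c2)cc(OC)c1OC`: 112 nM
- Compound 2 `CCn1ccc2cc(C(=O)c3cc(OC)c(OC)c(OC)c3)ccc21`: 38 nM
- Compound 3 `COc1cc(C(=O)c2ccc3c(ccn3C(C)C)c2)cc(OC)c1OC`: 1600 nM

These three share one core and differ only in what sits on the aromatic nitrogen. Compound 3 is the weakest inhibitor of the three, at 1600 nM. Compound 4 `COc1cc(C(=O)c2ccc3c(ccn3CCN(C)C)c2)cc(OC)c1OC` comes from it by a single exchange: 2-(dimethylamino)ethyl in place of isopropyl on an aromatic nitrogen. Among the compounds with values here, no measured compound carries a chain like 2-(dimethylamino)ethyl, so the nearest evidence is the other changes on that same nitrogen. Ethyl in place of hydrogen gave a modest step, a 2.9-fold lower number from compound 1 to compound 2 (0.47 log units; beyond the scatter). Isopropyl in place of hydrogen gave a large step the other way, a 14-fold higher number from compound 1 to compound 3 (1.15 log units; beyond the scatter). The biggest step is the one that adds a single methyl to the chain carbon bound to the aromatic nitrogen, a 42-fold higher number from compound 2 to compound 3 (1.62 log units; beyond the scatter). The new group lacks that extra methyl, as does the ethyl of compound 2 at 38 nM. As far as these compounds go, a large step towards lower numbers in this assay is therefore expected, though probably not all the way back to compound 2, since the longer chain is untested. The expected change is an 11-fold lower number from compound 3 to compound 4 (1.03 log units; beyond the scatter). For compound 4 the estimated value is 150 nM, with an expected range from 30 nM to 700 nM.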

Compound 4, half-maximal inhibitory concentration: 5100 nM
Estimate against measurement, compound 4: 34-fold (1.53 log units) below; the whole stated range lies below it.
By their numbers in this assay, from the lowest: compound 2; then compound 1; then compound 3; then compound 4.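

In this assay, leaving out the extra methyl on the chain carbon bound to the aromatic nitrogen is clearly not enough to bring back inhibition: 2-(dimethylamino)ethyl in place of isopropyl gives a 3.2-fold higher number from compound 3 to compound 4 (0.50 log units; beyond the scatter) and leaves compound 4 the weakest inhibitor of the four. What the chain carries beyond that carbon therefore matters as well, since dimethylamino in place of hydrogen on a saturated chain carbon, two bonds along the chain from the aromatic nitrogen, gives a 130-fold higher number from compound 2 to compound 4 (2.13 log units; beyond the scatter) and this is the largest step in the set. Measured against the free aromatic nitrogen, the new chain gives a 46-fold higher number from compound 1 to compound 4 (1.66 log units; beyond the scatter) and so joins isopropyl on the side of weaker inhibition, which leaves ethyl as the only group shown here that gives a lower number than hydrogen.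

Still open, as far as these compounds go, is whether a methyl, a propyl or a longer plain carbon chain would follow ethyl, and whether a chain ending in a morpholine ring or a carboxylic acid would follow the dimethylamino chain. Nothing measured here explains why the new chain gave this result.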